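The compounds below may be only part of what the source reports. "The series", "measured", "known", "first", "only" and "open" are said of these compounds alone.

Compound 1 `CC(=O)Nc1cc(NC(=O)Nc2cccc(C(C)=O)c2)ccc1C` and compound 2 `CC(=O)c1cccc(NC(=O)Nc2ccc(C)c(NC(=O)c3ccccc3)c2)c1` share one core; compound 3 `CC(=O)Nc1cc(NC(=O)c2cc(C)on2)ccc1C` and compound 4 `Cc1cc(C(=O)Nc2ccc(C)c(NC(=O)c3ccccc3)c2)no1` share another, and the difference between the two cores is not broken down here. In a functional assay on A375P cells (Homo sapiens) for antiproliferative activity (on this read-out lower numbers stand for stronger inhibition and higher numbers for weaker inhibition), compound 1 gives 22100 nM. In this assay compound 2 gives 9800 nM. Compound 2 differs from compound 1 by phenyl in place of methyl on a carbonyl carbon, a change that made a 2.3-fold lower number from compound 1 to compound 2 (0.35 log units; beyond the scatter). For compound 3 this assay reports only a limit, > 30000 nM, in line with the limit of > 30000 nM in this assay, at which 1 of the 3 values shown sits. Compound 4 differs from compound 3 by phenyl in place of methyl on a carbonyl carbon, the same change at the same place. The starting point for compound 3 is known only as a limit, so any figure for compound 4 carries wide bounds. The step from compound 3 to compound 4 in this assay is expected to be an at least 1.2-fold lower number from compound 3 to compound 4 (0.07 log units; that floor lies within the scatter). That expectation rests on the measured step of a 2.3-fold lower number from compound 1 to compound 2 (0.35 log units; beyond the scatter). Compound 4 is estimated at 25000 nM, between 8000 nM and 60000 nM.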

Compound 4, half-maximal inhibitory concentration: > 30000 nM
Compound 4 gave a limit, no number; the forecaster's own chance of this, stated with the estimate: 45%; at least 1.2-fold (0.07 log units) between middle value and limit.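

Compound 3 and compound 4 both stand only as limits in this assay, so no step between them can be read: the limit of > 30000 nM in this assay, at which 2 of the 4 values shown sit.

The compounds shown leave open whether phenyl in place of methyl on a carbonyl carbon changes the number on the core of compound 3.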